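Methoxy added to the chloropyridine of compound 2

A few compounds are considered here, and "the series" means these few. Any claim that something is new, unique, unknown or untested is made for them only; others in the source may bear on it.

Measured so far:
- compound 1, `CN1C[C@H]2C=C(c3cccnc3)C[C@H](C2)C1`: 2.1 nM
- compound 2, `CN1CC2C=C(c3ccc(Cl)nc3)CC(C2)C1`: 22 nM
- compound 3, `CN1CC2C=C(c3cnccc3Cl)CC(C2)C1`: 1160 nM

In an in vitro assay on SH-EP1 cells for displacement of a labelled ligand from Neuronal acetylcholine receptor; alpha4/beta2 (Homo sapiens) (on this read-out lower numbers stand for stronger inhibition and higher numbers for weaker inhibition), compound 2 gives 22 nM, the second highest of the three numbers. Compound 1, the nearest, gives 2.1 nM in this assay, a lower number beyond the scatter; compound 3, the furthest, gives 1160 nM, a much higher number, also beyond the scatter. Among the compounds with values here, no step between measured compounds that differ in one place is available, so the effect of a single change on the pyridine has not been isolated.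

Compound 4, `COc1cc(C2=CC3CC(C2)CN(C)C3)cnc1Cl`, differs from compound 2 in one place: methoxy in place of hydrogen on an aromatic carbon. The methoxy is placed on an aromatic carbon ortho to the chloro group, two atoms from the ring nitrogen and meta to the large group. Substitution on this ring has not been neutral so far, since compound 3 gives 1160 nM against compound 1 at 2.1 nM, so a change in this assay is expected. The step from compound 2 to compound 4 is estimated as a 2.7-fold higher number from compound 2 to compound 4 (0.44 log units; beyond the scatter), a moderate rise, with wide uncertainty. Compound 4 is expected to give about 60 nM, within 15 nM to 250 nM.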

Compound 4, inhibition constant: 4.4 nM
For compound 4 the middle estimate is 14-fold (1.13 log units) above the measured one; measured number below the stated range.
By their numbers in this assay, from the lowest: compound 1; then compound 4; then compound 2; then compound 3.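

In this assay, methoxy in place of hydrogen on an aromatic carbon, ortho to a chloro group and two atoms from the ring nitrogen, brings a 5.0-fold lower number from compound 2 to compound 4 (0.70 log units; beyond the scatter). Within the data shown here, as the first single-change step, this shows that the carbon takes a group of 2 heavy atoms with stronger rather than weaker inhibition. No measurement at hand accounts for the direction or size of this step.

Going by these compounds, it remains open whether the gain is particular to methoxy or would also appear with a hydroxyl, an amine or a longer alkoxy chain on the same carbon. Also open, on these data alone, is whether methoxy gives a similar step without the chloro group, on the unsubstituted pyridine of compound 1.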